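Swapping the Benzoyl Arm of an Inactive Acylurea

This account rests on a few compounds, and the source may have more. Where it says the series, first, only, none or still open, it means among the compounds named here.

Compound 1, `CN(C(=O)NC(=O)c1ccc(C(F)(F)F)cc1)c1nc(C(F)(F)F)c(C(=O)N/N=C/c2ccc(C(F)(F)F)cc2)s1`, in a functional assay on HepG2 cells (Homo sapiens) for inhibition, read by MTT assay, with a stated time of 72 h (on this read-out lower numbers stand for stronger inhibition and higher numbers for weaker inhibition), gives > 100 ug/mL, which is a limit of the assay and not a number.
Compound 2, `CN(C(=O)NC(=O)c1ccc(C(F)(F)F)cc1)c1nc(C(F)(F)F)c(C(=O)N/N=C/c2cccc(C(F)(F)F)c2)s1`, gives 7.95 ug/mL.
Compound 3, `Cc1nc(N(C)C(=O)NC(=O)c2c(F)cccc2F)sc1C(=O)N/N=C/c1cc(C(F)(F)F)cc(C(F)(F)F)c1`, gives 11.4 ug/mL.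

Compound 1 therefore stands at the edge of what this assay can report, namely (the limit of > 100 ug/mL in this assay, at which 1 of the 3 values shown sits); nothing more exact is known for it. Going by the values given here, the only measured step that starts from compound 1 is an at least 12-fold lower number from compound 1 to compound 2 (1.09 log units; beyond the scatter), a large change that moves the aryl group on the carbon with a double bond to nitrogen and brings the value onto the scale.

Compound 4, `CN(C(=O)NC(=O)c1ccccc1F)c1nc(C(F)(F)F)c(C(=O)N/N=C/c2ccc(C(F)(F)F)cc2)s1`, makes a different change: 2-fluorophenyl in place of 4-(trifluoromethyl)phenyl on a carbonyl carbon. Among the compounds with values here, no measured pair of compounds differs in just this place, so no measured step bears directly on it. Within the data shown here, compound 3 also carries a fluorinated benzoyl group, but it differs from compound 1 in several places at once, so its value shows only that a member of this family with such a group can be active.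

Compound 4 keeps the same aryl group on the carbon with the double bond to nitrogen that compound 1 has, so only a modest step is expected, an at least 1.2-fold lower number from compound 1 to compound 4 (0.09 log units; that floor lies within the scatter), with a real chance that again only a limit is reported. Compound 4 is expected to give about 80 ug/mL, within a range from 20 ug/mL to 300 ug/mL.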

Compound 4, half-maximal inhibitory concentration: 4.56 ug/mL
Compound 4: middle estimate off by 18-fold (1.24 log units), on the high side, outside the stated range (below it).
By their numbers in this assay, from the lowest: compounds 4, 2 and 3 (each within the scatter of the next, the first and the last beyond it). At a limit, above all of these: compound 1.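

Up to this point, the only measured way off the limit lay in the aryl group on the carbon with a double bond to nitrogen, and the carbonyl end of the acylurea had no step of its own. Placing 2-fluorophenyl in place of 4-(trifluoromethyl)phenyl on a carbonyl carbon now gives an at least 21-fold lower number from compound 1 to compound 4 (1.34 log units; beyond the scatter), while the 4-(trifluoromethyl)phenyl on the carbon with the double bond to nitrogen stays as it was, so that group alone does not hold a compound of this family at the limit in this assay. The step is a floor and not an exact size because compound 1 has only a limit, not a number: the limit of > 100 ug/mL in this assay, at which 1 of the 4 values shown sits.

This single swap removes a trifluoromethyl group and adds a fluorine at once, so the compounds shown cannot separate the two, and a plain phenyl or a 4-methylphenyl on that carbonyl carbon would be needed to tell them apart. Also open, as far as these compounds go, is what a compound would give with 2-fluorophenyl on the carbonyl carbon together with 3-(trifluoromethyl)phenyl on the carbon with the double bond to nitrogen, joining the two changes that each left the limit.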